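Swapping Trifluoromethyl for Methyl in a Kinase Inhibitor Series

The source may hold more compounds than are shown below. What is called first, only, known or untested is meant among the compounds shown, and "the series" means these compounds.

Among the measured compounds shown here, compound 2 `Cc1c(C(=O)Nc2ccc(Oc3ncnc4[nH]cc(-c5ccccc5)c34)c(F)c2)c(=O)c2cc(C(F)(F)F)ccc2n1C` is the one compound in this set with a measured number: in an assay on isolated protein for inhibition of tyrosine-protein kinase receptor UFO (Homo sapiens), read by FRET and Z'-LYTE, with a stated time of 1.5 h (on this read-out higher numbers stand for weaker inhibition and lower numbers for stronger inhibition), compound 2 gives 150 nM. Compound 1 `Cc1c(C(=O)Nc2ccc(Oc3ncnc4[nH]cc(-c5ccccc5)c34)c(F)c2)c(=O)c2ccccc2n1C` differs from it only by a hydrogen where compound 2 carries trifluoromethyl. For compound 1 the result in this assay is > 10000 nM, which is a limit of the assay and not a number, so compound 1 sits at the limit of > 10000 nM in this assay, at which 1 of the 2 values shown sits. The step of an at least 66-fold lower number from compound 1 to compound 2 (1.82 log units; beyond the scatter) therefore shows that the trifluoromethyl group carries much of the inhibition seen here. Compound 3 `Cc1ccc2c(c1)c(=O)c(C(=O)Nc1ccc(Oc3ncnc4[nH]cc(-c5ccccc5)c34)c(F)c1)c(C)n2C` goes partway back: methyl in place of trifluoromethyl on an aromatic carbon. For the measured compounds named here, only that one measured step bears on this change, and it was large. Since methyl lies between hydrogen and trifluoromethyl in what it brings, the step of a 6.7-fold higher number from compound 2 to compound 3 (0.82 log units; beyond the scatter) is expected to move toward weaker inhibition without reaching the limit. Compound 3 is therefore estimated at 1000 nM, with a range from 200 nM to 5000 nM.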

Compound 3, half-maximal inhibitory concentration: 100 nM
Beside the measured number, compound 3's estimate is 10-fold (1.00 log units) above it, and the stated range ends above it.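

The step of a 1.5-fold lower number from compound 2 to compound 3 (0.18 log units; within the scatter) means that in this assay, methyl and trifluoromethyl cannot be told apart at this position. The step of an at least 100-fold lower number from compound 1 to compound 3 (2.00 log units; beyond the scatter) shows that the much smaller methyl gives the same large gain over hydrogen, so among these three compounds, the inhibition does not depend on the fluorine atoms and what separates them is whether this carbon carries hydrogen or one of these two groups. The value for compound 1 is a limit of the assay and not a number: the limit of > 10000 nM in this assay, at which 1 of the 3 values shown sits.

As far as these compounds go, it remains open whether a longer chain such as ethyl, a methoxy group, an amine or a carboxylic acid would keep this inhibition at the same position. These compounds also leave open how far the position tolerates larger groups, and whether methyl and trifluoromethyl would still match on another core.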